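This account rests on a few compounds, and the source may have more. Where it says the series, first, only, none or still open, it means among the compounds named here.

Series notes on the shared core of compound 1 `c1ccc(CN2CCN(CCCc3c[nH]c4ccc(-n5cnnc5)cc34)CC2)nc1`. In an assay on CHO cells for displacement of a labelled ligand from 5-hydroxytryptamine receptor 1B (Homo sapiens) (on this read-out higher numbers stand for weaker inhibition and lower numbers for stronger inhibition), compound 1 gives 18 nM, compound 2 `c1cc(CN2CCN(CCCc3c[nH]c4ccc(-n5cnnc5)cc34)CC2)ccn1` gives 23 nM and compound 3 `c1c[nH]c(CN2CCN(CCCc3c[nH]c4ccc(-n5cnnc5)cc34)CC2)n1` gives 36 nM, the top number of the three, though a 2.0-fold higher number from compound 1 to compound 3 (0.30 log units; within the scatter) and a 1.6-fold higher number from compound 2 to compound 3 (0.19 log units; within the scatter) are both within the scatter, as is a 1.3-fold higher number from compound 1 to compound 2 (0.11 log units; within the scatter). Compound 4 `FC(F)(F)c1ccc(CN2CCN(CCCc3c[nH]c4ccc(-n5cnnc5)cc34)CC2)cc1` carries 4-(trifluoromethyl)phenyl in place of 1H-imidazol-2-yl on a saturated chain carbon bound to an amine nitrogen in a ring. The three measured steps each exchange one small heteroaryl for another and none went beyond the scatter; none brings in a carbon-only ring or a trifluoromethyl, so they bear only loosely on this step. Expected for compound 4 in this assay is a step of a 1.1-fold higher number from compound 3 to compound 4 (0.05 log units; within the scatter), with no direction asserted beyond the scatter. Estimated value for compound 4: 40 nM, range 12 nM to 130 nM.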

Compound 4, half-maximal inhibitory concentration: 282 nM
Estimate against measurement, compound 4: 7.1-fold (0.85 log units) below; the measured number lies above the stated range.
By their numbers in this assay, from the lowest: compounds 1, 2 and 3 (each within the scatter of the next); then compound 4.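

At this place, on a saturated chain carbon bound to an amine nitrogen in a ring, the heteroaryl exchanges stayed within the scatter, but 4-(trifluoromethyl)phenyl moves the number beyond it in this assay (a 7.8-fold higher number from compound 3 to compound 4 (0.89 log units; beyond the scatter); a 12-fold higher number from compound 2 to compound 4 (1.09 log units; beyond the scatter); a 16-fold higher number from compound 1 to compound 4 (1.19 log units; beyond the scatter)). All three steps run towards weaker inhibition, so this position does not accept every aromatic ring alike. Nothing shown accounts for the loss. Still open, on these data alone, is whether the loss follows the carbon-only ring or the trifluoromethyl, which a plain phenyl in the same place would help to separate.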